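This account rests on a few compounds, and the source may have more. Where it says the series, first, only, none or still open, it means among the compounds named here.

Working notes on the series. Four compounds share one core, seen in compound 1 `C=CC(=O)Nc1cccc(Nc2ncnc(Nc3ccc(C(=O)Nc4ccccn4)cc3)n2)c1`, compound 2 `C=CC(=O)Nc1cccc(Nc2ncnc(Nc3ccc(-c4ccc(C)nc4)cc3)n2)c1`, compound 3 `C=CC(=O)Nc1cccc(Nc2ncnc(Nc3ccc(OC)cc3)n2)c1` and compound 4 `C=CC(=O)Nc1cccc(Nc2ncnc(Nc3ccc(-c4ccc(F)nc4)cc3)n2)c1`. In a functional assay on Ramos cells (Homo sapiens) for antiproliferative activity, read by CCK-8 assay, with a stated time of 24 h (a lower number here means a stronger inhibitor, a higher number a weaker inhibitor), compound 1 stands at "not determined" (no result reported), and compound 2 likewise at "not determined" (no result reported). Among the compounds with values here, compound 3 is the only member with a number in this assay, where compound 3 gives 90000 nM, a weak result. Compound 4 differs from compound 3 by 6-fluoropyridin-3-yl in place of methoxy on an aromatic carbon. Within the data shown here, no measured step is available to scale this change, so the expectation rests on compound 3 alone and is uncertain. The step from compound 3 to compound 4 is expected to be a 3.0-fold lower number from compound 3 to compound 4 (0.48 log units; beyond the scatter), toward stronger inhibition and beyond the scatter. Compound 4 is estimated at 30000 nM, between 5000 nM and 100000 nM.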

Compound 4, half-maximal inhibitory concentration: 59200 nM
Estimate against measurement, compound 4: 2.0-fold (0.30 log units) below; the measured number falls inside the stated range.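

Within the data shown here, the step of a 1.5-fold lower number from compound 3 to compound 4 (0.18 log units; within the scatter) in this assay lies within the scatter, the first measured change at this position. Exchanging methoxy for 6-fluoropyridin-3-yl, which brings a six-membered aromatic ring onto the aromatic carbon para to a large group, therefore gives no shift that can be told apart, and both compounds remain weak. From the compounds shown here alone, whether a small amine or a carboxylic acid on this carbon would move the number beyond the scatter stays open, as does the effect of the fluorine, since compound 2 offers no number for comparison. Nothing at hand bears on a cause.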